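The source may report more compounds than this note shows. Statements on the series, on what has been measured and on what is new or still open speak of the compounds shown alone.

Measured so far in an assay on V79 cells for inhibition of cytochrome P450 11B2, mitochondrial (Homo sapiens), read by HTRF, with a stated time of 1 h; on this read-out higher numbers stand for weaker inhibition and lower numbers for stronger inhibition:
compound 1 `Cn1c(-c2cccnc2)nc2ccc(F)cc21` — 12 nM
compound 2 `Cc1ccncc1-c1nc2cc(F)c(F)cc2n1C1CC1` — 10.2 nM
compound 3 `COc1cncc(-c2nc3cc(F)c(F)cc3n2C2CC2)c1` — 0.4 nM

Compound 1 gives the highest of these three numbers; compound 2 sits within the scatter of it, whereas compound 3 gives a far lower number, beyond the scatter. Compound 4 `Fc1ccc2nc(-c3cccnc3)n(C3CCC3)c2c1` has not yet been measured. It differs from compound 1 in one place: cyclobutyl in place of methyl on an aromatic nitrogen, on an aromatic nitrogen of the five-membered ring of the shared core. For the measured compounds named here, no measured pair differs only in this way, so the size of the step is uncertain. Compounds 2 and 3 carry a cyclopropyl on that nitrogen together with other changes, and neither gives a weaker number than compound 1. Compound 4 is therefore expected to give about 6 nM (range 1.5 nM to 25 nM), an estimated step of a 2.0-fold lower number from compound 1 to compound 4 (0.30 log units; within the scatter), small and possibly within the scatter.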

Compound 4, half-maximal inhibitory concentration: > 5000 nM
Compound 4: no number, only a limit; the forecaster's own chance of this, stated with the estimate: 2%; middle value at least 830-fold (2.92 log units) from the limit.
By their numbers in this assay, from the lowest: compound 3; then compounds 2 and 1 (each within the scatter of the next). At a limit, above all of these: compound 4.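

On the core of compound 1, this nitrogen proves highly sensitive to the group it carries: cyclobutyl in place of methyl brings an at least 410-fold higher number from compound 1 to compound 4 (2.61 log units; beyond the scatter), a large loss of inhibition in this assay. Compound 4 gives > 5000 nM, which is a limit of the assay and not a number. From the compounds shown here alone, a single change at this position can therefore take inhibition out of the measured range, though the full size of the step remains unknown. The compounds shown leave open how an ethyl or isopropyl group on this nitrogen would compare with methyl and cyclobutyl.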